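Replacing the Ethyl Chain on the Core with an Allyl

A few compounds are considered here, and "the series" means these few. Any claim that something is new, unique, unknown or untested is made for them only; others in the source may bear on it.

Among the measured compounds shown here, compound 1 `CCn1c(N[C@@H]2C[C@H](c3ccccc3)CN(C)C2)nc2cc[nH]c2c1=O` was tested in an assay on isolated protein for binding affinity to histone acetyltransferase KAT2B (Homo sapiens), read by fluorescence, tested at 10 uM (on this read-out higher numbers stand for stronger stabilisation of the target against heat and lower numbers for weaker stabilisation of the target), where compound 1 gives 4.8 degrees C. Among the two compounds measured so far, compound 1 stands lowest. Its nearest neighbour is compound 2 `CN1C[C@H](Nc2nc3cc[nH]c3c(=O)n2C)C[C@H](c2ccc(OC(F)(F)F)cc2)C1`, and in this assay compound 2 gives 5.9 degrees C, a number higher than that of compound 1 by more than the usual scatter.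

Compound 3 `C=CCn1c(N[C@@H]2C[C@H](c3ccccc3)CN(C)C2)nc2cc[nH]c2c1=O` has not yet been measured. It differs from compound 1 in a single place: vinyl in place of methyl on a saturated chain carbon bound to an aromatic nitrogen. For the measured compounds named here, no measured pair of compounds shows a change of this kind, so there is nothing to compare it with directly. A change of this small size, adding no ring and no hydrogen-bond donor or acceptor, is expected to move the number little. The step of no change at the digits printed from compound 1 to compound 3 (within the scatter) is expected to fall within the scatter, in no clear direction. For compound 3 the estimate is 4.8 degrees C, with a range from 3.3 degrees C to 6.3 degrees C.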

Compound 3, shift of the target's melting temperature: 2.2 degrees C
Compound 3: the middle estimate sits 2.6 degrees C above what was measured; measured number outside the range, below it.
By their numbers in this assay, from the lowest: compound 3; then compound 1; then compound 2.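

Changing ethyl to allyl gives a number 2.6 degrees C lower from compound 1 to compound 3 (beyond the scatter) in this assay, so this place on the molecule, a saturated chain carbon bound to an aromatic nitrogen, does respond to a small edit. The change adds a double bond but no ring and no hydrogen-bond donor or acceptor, so a read-out change of this size does not require a large structural change at this place. No measurement shown here accounts for the drop.

A single pair cannot separate the double bond from the longer chain, and a saturated propyl group on the same nitrogen would be the direct test of that. As far as these compounds go, it also remains open whether a chain ending in an amine or a carboxylic acid would be treated differently at this place.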